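A few compounds are considered here, and "the series" means these few. Any claim that something is new, unique, unknown or untested is made for them only; others in the source may bear on it.

Measured compounds:
compound 1, `Cc1c(OCCCCOc2ccc(C(=O)O)cc2)ccc(C(=O)CC2CCCC2)c1O`, 26.7% in an assay on HEK293 cells for positive allosteric modulation of metabotropic glutamate receptor 3 (Rattus norvegicus), read by thallium flux, with a stated time of 2.5 min; on this read-out lower numbers stand for smaller maximal responses and higher numbers for larger maximal responses;
compound 2, `Cc1c(OCCCCOc2ccc(C(=O)O)cc2F)ccc(C(=O)CC2CCCC2)c1O`, 31.2% in this assay;
compound 3, `Cc1c(OCCCCOc2ccc(F)c(C(=O)O)c2)ccc(C(=O)CC2CCCC2)c1C`, 12.6% in this assay.

Compound 4, `Cc1c(OCCCCOc2cccc(C(=O)O)c2)ccc(C(=O)CC2CCCC2)c1C`, is not yet measured. Compound 2 and compound 1 differ by hydrogen in place of fluoro on an aromatic carbon, and this gave a number 4.5 percentage points lower from compound 2 to compound 1 (within the scatter). Compound 3 and compound 4 differ by hydrogen in place of fluoro on an aromatic carbon, the same kind of change, but here the place is ortho to a carboxy group and para to a large group, whereas in compound 2 it is ortho to a large group and meta to a carboxy group. The difference between the core of compound 3 and the core of compound 2 is not broken down here. Because the earlier step of a number 4.5 percentage points lower from compound 2 to compound 1 (within the scatter) stayed within the scatter, compound 4 is expected to move only a little, a number 1.6 percentage points lower from compound 3 to compound 4 (within the scatter). The estimate for compound 4 in this assay is 11%, from 3% to 22%.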

Compound 4, largest response reached (reported as percent of maximum), in percent of the reference or control that the assay uses: 16.5%
For compound 4 the middle estimate is 5.5 percentage points below the measured one; the measured number falls inside the stated range.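

In this assay, hydrogen in place of fluoro gave a number 3.9 percentage points higher from compound 3 to compound 4 (within the scatter), so the change stayed small on this core as well. Set beside the earlier step, the result on the two cores does not differ: the same change on two cores in this assay, a number 4.5 percentage points lower (within the scatter) from compound 2 to compound 1 and a number 3.9 percentage points higher (within the scatter) from compound 3 to compound 4, 8.4 percentage points apart, within the scatter of two such steps This shows that the change carried over between these two cores without a measurable effect on either, but the two steps sit at different places on the ring, and they establish no rule for other cores or places.

The compounds shown leave open whether chloro, methoxy or a nitrile in that place would shift the response further. They also leave open what a tetrazole in place of the carboxylic acid, or a longer chain, would do.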